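The source may report more compounds than this note shows. Statements on the series, on what has been measured and on what is new or still open speak of the compounds shown alone.

In an ADME assay on MRC5 cells (Homo sapiens) for cytotoxicity, read by fluorescence, with a stated time of 72 h (on this read-out higher numbers stand for weaker inhibition and lower numbers for stronger inhibition), compound 1 (`CC1(COc2ccc(OC(F)(F)F)cc2)Cn2cc([N+](=O)[O-])nc2O1`) gives > 64000 nM and this is a limit. Compound 2 (`CC1(COc2ccccc2)Cn2cc([N+](=O)[O-])nc2O1`) gives > 64000 nM which is likewise a limit. Compound 3 (`CC1(COc2ccc(Oc3ccccc3)cc2)Cn2cc([N+](=O)[O-])nc2O1`) gives > 64000 nM which is also a limit. Compound 1 thus stands level with the other two measured compounds only in the sense that no number exists for any of them. Compound 4 (`CSc1cn2c(n1)OC(C)(COc1ccc(OC(F)(F)F)cc1)C2`) carries methylsulfanyl in place of nitro on an aromatic carbon. The measured steps are a step that the two limits leave unreadable from compound 1 to compound 2 and a step that the two limits leave unreadable from compound 1 to compound 3 and finally a step that the two limits leave unreadable from compound 2 to compound 3 with no size to carry over. None of them replaces the nitro group, so none bears directly on this change. Among the measured compounds shown here, the only guide is compound 1 at > 64000 nM as a limit, so compound 4 is expected to remain near that limit, with no step beyond the scatter and no direction to forecast. The expected change is a number no higher from compound 1 to compound 4 (the limit leaves the size open) as estimated here. For compound 4 the estimate is 64000 nM with an expected range from 25000 nM to 64000 nM on present data.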

Compound 4, half-maximal inhibitory concentration: 38000 nM
The estimate for compound 4 lay 1.7-fold (0.23 log units) above the measured number, within the range that was stated.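

In this assay, among the compounds shown here, methylsulfanyl in place of nitro on an aromatic carbon of the five-membered aromatic ring gives the first readable number, with an at least 1.6-fold lower number from compound 1 to compound 4 (0.22 log units; that floor lies within the scatter). The printed floor of that step lies within the scatter. The result does not establish a change beyond it. The steps among compound 1, compound 2 and compound 3 cannot be read and none of them replaces nitro, so this is the only change shown that yields a value under the limit of the assay: the limit of > 64000 nM in this assay, at which 3 of the 4 values shown sit.

From the compounds shown here alone, the true size of the step stays open, since compound 1 has only a limit. Also open, going by these compounds, is how an amine, a carboxylic acid or a longer sulfur-linked chain on this aromatic carbon would read, and whether methylsulfanyl gives a number with the aryl ends of compound 2 and compound 3.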